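Changing the Chain-End Group: From Compound 3 to Compound 4

This account rests on a few compounds, and the source may have more. Where it says the series, first, only, none or still open, it means among the compounds named here.

Compound 1, `C/N=C(/NC#N)NCCCCCCn1nc(-c2ccccc2)ccc1=O`: in a functional assay on the whole organism (stomach) with Rattus norvegicus as the target (a lower number here means that less compound is needed, a higher number that more compound is needed for the effect), compound 1 gives > 100 mg/kg, which is a limit of the assay and not a number.
Compound 2, `CC/N=C(/NC#N)NCCCCn1nc(-c2ccccc2)ccc1=O`: in this assay compound 2 gives 92 mg/kg.
Compound 3, `C/N=C(/NC#N)NCCCCCn1nc(-c2ccccc2)ccc1=O`: in this assay compound 3 gives 100 mg/kg.

Among the numbers shown, compound 3 stands level with compound 2, since a 1.1-fold higher number from compound 2 to compound 3 (0.04 log units; within the scatter). The step from the limit of compound 1 is open in size: a number no higher from compound 1 to compound 3 (the limit leaves the size open). Compound 4, `CN(C)/C(=N/CCCCCn1nc(-c2ccccc2)ccc1=O)NC#N`, differs from compound 3 by a group of 8 heavy atoms (4 carbon, 4 nitrogen; no ring) in place of a group of 7 heavy atoms (3 carbon, 4 nitrogen; no ring), on a saturated chain carbon, five bonds along the chain from an aromatic nitrogen. Both measured steps alter this same chain-end group, and neither shows a change beyond the scatter, so for compound 4 in this assay no step beyond the scatter is expected: no change at the digits printed from compound 3 to compound 4 (within the scatter). Compound 4 is therefore estimated at 100 mg/kg, with a range from 40 mg/kg to 250 mg/kg.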

Compound 4, dose for half-maximal effect: 81.5 mg/kg
Compound 4: middle estimate off by 1.2-fold (0.09 log units), on the high side, within the range that was stated.
By their numbers in this assay, from the lowest: compounds 4, 2 and 3 (each within the scatter of the next).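

The group entering at compound 4 has 1 hydrogen-bond donor where the group leaving had 2, on a saturated chain carbon, five bonds along the chain from an aromatic nitrogen, and in this assay this swap gives a 1.2-fold lower number from compound 3 to compound 4 (0.09 log units; within the scatter). Set against a limit of the assay, the comparison gives only a floor: an at least 1.2-fold lower number from compound 1 to compound 4 (0.08 log units; that floor lies within the scatter). Compound 1 stays a limit and not a number: the limit of > 100 mg/kg in this assay, at which 1 of the 4 values shown sits.

Still open, from the compounds shown here alone, is whether any chain-end group moves this number beyond the scatter. A carboxylic acid or an amine in place of this group would test that.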